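Methoxy on the pyrazoline phenyl of a weak inhibitor

The source may report more compounds than this note shows. Statements on the series, on what has been measured and on what is new or still open speak of the compounds shown alone.

Measured compounds:
Compound 1 `Cn1c(N2N=C(c3ccccc3)CC2c2ccccc2)nc(-c2ccccc2)c(C#N)c1=O`: 3990 nM
Compound 2 `Cn1c(N2N=C(c3ccc(Cl)cc3)CC2c2ccccc2)nc(-c2ccccc2)c(C#N)c1=O`: 10600 nM
Compound 3 `Cn1c(N2N=C(c3ccccc3)CC2c2ccccc2)nc(-c2ccc(Cl)cc2)c(C#N)c1=O`: 29100 nM

In a functional assay on MDA-MB-231 cells (Homo sapiens) for antiproliferative activity, with a stated time of 72 h (a higher number here means a weaker inhibitor, a lower number a stronger inhibitor), compound 1 gives 3990 nM. Compound 2 gives 10600 nM, and compound 3 gives 29100 nM, the highest of the three numbers; its steps to compound 2 and to compound 1 are both beyond the scatter, so compound 3 is the weakest inhibitor measured here. Both measured steps are chloro in place of hydrogen on an aromatic carbon: a 2.7-fold higher number from compound 1 to compound 2 (0.42 log units; beyond the scatter) and a 7.3-fold higher number from compound 1 to compound 3 (0.86 log units; beyond the scatter). Compound 4 `COc1ccc(C2CC(c3ccccc3)=NN2c2nc(-c3ccc(Cl)cc3)c(C#N)c(=O)n2C)cc1` differs from compound 3 by methoxy in place of hydrogen on an aromatic carbon, that is, phenyl to 4-methoxyphenyl on the ring at the saturated carbon of the pyrazoline. For the measured compounds named here, no measured step covers a methoxy at any position, and the chloro steps concern other rings, so neither bears directly on this change. The expectation is therefore of no step beyond the scatter, a 1.0-fold higher number from compound 3 to compound 4 (0.01 log units; within the scatter), with wide uncertainty. Compound 4 is estimated at 30000 nM, between 10000 nM and 90000 nM.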

Compound 4, half-maximal inhibitory concentration: 19500 nM
Compound 4: middle estimate off by 1.5-fold (0.19 log units), on the high side; the measured number falls inside the stated range.
By their numbers in this assay, from the lowest: compound 1; then compounds 2, 4 and 3 (each within the scatter of the next, the first and the last beyond it).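

In this assay, the change from phenyl to 4-methoxyphenyl gives a 1.5-fold lower number from compound 3 to compound 4 (0.17 log units; within the scatter). For the compounds shown here, this is the first reading for this ring, which neither chloro step touched, and it shows that a methoxy can enter here, on an aromatic carbon para to a large group, without a step beyond the scatter when the chloro of compound 3 is present. Nothing available explains this outcome or shows what the methoxy does in these cells.

The compounds shown leave open whether the same methoxy would have as small a step on the unchlorinated compound 1. They also leave open whether an amine, a carboxylic acid or a longer chain at this place would move the number beyond the scatter.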